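The compounds below may be only part of what the source reports. "The series", "measured", "known", "first", "only" and "open" are said of these compounds alone.

Of the compounds shown here, three have so far been measured in an ADME assay on HEK-293T cells (Homo sapiens) for cytotoxicity, read by MTT assay, with a stated time of 24 h; on this read-out higher numbers stand for lower toxicity in this test and lower numbers for higher toxicity in this test. Compound 1 `O=C(c1ccncc1)n1c(-c2cn(-c3ccccc3)nc2-c2ccc(C(F)(F)F)cc2)nc2ccccc21` gives 135000 nM. Compound 2 `Cc1ccccc1C(=O)n1c(-c2cn(-c3ccccc3)nc2-c2ccc(C(F)(F)F)cc2)nc2ccccc21` gives 179000 nM. Compound 3 `Cc1ccc(-c2nn(-c3ccccc3)cc2-c2nc3ccccc3n2C(=O)c2cccnc2)cc1` gives 189000 nM, which is the highest of the three numbers, although its gaps to compound 2 and to compound 1 both lie within the scatter, so no order among the three can be read from them. Going by the values given here, the only measured step, a 1.3-fold higher number from compound 1 to compound 2 (0.12 log units; within the scatter), exchanges the group on the carbonyl carbon and leaves the number within the scatter.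

Compound 4 `O=C(c1cccnc1)n1c(-c2cn(-c3ccccc3)nc2-c2ccc(C(F)(F)F)cc2)nc2ccccc21` differs from compound 3 in one place: trifluoromethyl in place of methyl on an aromatic carbon. Among the compounds with values here, no measured step exchanges these two groups, so nothing measured bears on it directly. What the numbers do show is that compound 1 and compound 2, which carry the trifluoromethyl group, and compound 3, which carries the methyl group, all fall within the scatter of one another in this assay. On that basis the step from compound 3 to compound 4 is expected to stay within the scatter, a 1.2-fold lower number from compound 3 to compound 4 (0.07 log units; within the scatter). Compound 4 is therefore estimated at 160000 nM, with a range from 80000 nM to 320000 nM.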

Compound 4, half-maximal cytotoxic concentration: 158000 nM
Compound 4: the middle estimate sits 1.0-fold (0.01 log units) above what was measured; low and high end bracket the measured number.
By their numbers in this assay, from the lowest: compounds 1, 4, 2 and 3 (each within the scatter of the next).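

Going by these compounds alone, the first measured exchange at this position, 4-(trifluoromethyl)phenyl in place of 4-methylphenyl with pyridin-3-yl held on the carbonyl carbon, gives a 1.2-fold lower number from compound 3 to compound 4 (0.08 log units; within the scatter) in this assay, so this change leaves the number within the scatter. With the 4-(trifluoromethyl)phenyl group held, two exchanges on the carbonyl carbon also stay within the scatter: pyridin-3-yl in place of 2-methylphenyl gives a 1.1-fold lower number from compound 2 to compound 4 (0.05 log units; within the scatter) and pyridin-3-yl in place of pyridin-4-yl gives a 1.2-fold higher number from compound 1 to compound 4 (0.07 log units; within the scatter) in this set. Nothing available speaks to a cause for any of these results.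

The compounds shown leave open whether an amine or a carboxylic acid in place of trifluoromethyl on that ring, or a longer chain in place of the aromatic group on the carbonyl carbon, would carry the number beyond the scatter. They also leave open whether the exchange of 4-methylphenyl for 4-(trifluoromethyl)phenyl reads the same with pyridin-4-yl or 2-methylphenyl on the carbonyl carbon.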